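Swapping the Aryl Group on a Hydrazone-Linked Core

A few compounds are considered here, and "the series" means these few. Any claim that something is new, unique, unknown or untested is made for them only; others in the source may bear on it.

The measured compounds and their values:

Compound 1, `Cn1c(=O)c(=O)n(C2CCCC2)c2nc(N/N=C/c3ccc(F)c(Cl)c3)ncc21`, in a functional assay on PC-3 cells (Homo sapiens) for antiproliferative activity, read by MTT assay (a lower number here means a stronger inhibitor, a higher number a weaker inhibitor), compound 1 gives 8550 nM.
Compound 2, `Cc1ccc(/C=N/Nc2ncc3c(n2)n(C2CCCC2)c(=O)c(=O)n3C)cc1C`, in this assay compound 2 gives 39000 nM.
Compound 3, `Cn1c(=O)c(=O)n(C2CCCC2)c2nc(N/N=C/c3ccc(F)cc3Br)ncc21`, in this assay compound 3 gives 9250 nM.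

All three share a core and differ only in the aryl group attached to the carbon with a double bond to nitrogen. Compound 3 stands close to compound 1, the step being a 1.1-fold higher number from compound 1 to compound 3 (0.03 log units; within the scatter), while compound 2 sits apart, with a 4.2-fold lower number from compound 2 to compound 3 (0.62 log units; beyond the scatter). Compound 1 to compound 2 likewise shows a 4.6-fold higher number from compound 1 to compound 2 (0.66 log units; beyond the scatter).

Compound 4, `CSc1ccc(/C=N/Nc2ncc3c(n2)n(C2CCCC2)c(=O)c(=O)n3C)cc1`, has not yet been measured. The change from compound 3 is 4-(methylsulfanyl)phenyl in place of 2-bromo-4-fluorophenyl on a carbon with a double bond to nitrogen. Both measured steps at this position bear on it: exchanging one halogen-bearing phenyl for another left the number essentially unchanged, whereas the 3,4-dimethylphenyl of compound 2 gave a modestly higher number. The 4-(methylsulfanyl)phenyl carries no halogen, so a modest rise in this assay is expected, with a step of a 2.2-fold higher number from compound 3 to compound 4 (0.33 log units; beyond the scatter). Compound 4 is estimated at 20000 nM, within a range of 6000 nM to 60000 nM.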

Compound 4, half-maximal inhibitory concentration: 21000 nM
Beside the measured number, compound 4's estimate is 1.1-fold (0.02 log units) below it; the measured number falls inside the stated range.
By their numbers in this assay, from the lowest: compounds 1 and 3 (each within the scatter of the next); then compounds 4 and 2 (each within the scatter of the next).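

In this assay, the four aryl groups at this position now fall into two sets: the 4-(methylsulfanyl)phenyl of compound 4 does not match either halogen-bearing phenyl (a 2.3-fold higher number from compound 3 to compound 4 (0.36 log units; beyond the scatter) and a 2.5-fold higher number from compound 1 to compound 4 (0.39 log units; beyond the scatter)), yet it cannot be told apart from the 3,4-dimethylphenyl (a 1.9-fold lower number from compound 2 to compound 4 (0.27 log units; within the scatter)). Among these four compounds, the two with a halogen on the phenyl ring give the lower numbers and the two without one give the higher numbers, and none goes against this. Nothing available here explains why these groups differ.

As far as these compounds go, it remains open whether a phenyl ring carrying an amine, a carboxylic acid or a longer alkyl chain would join the lower set or the higher one. An unsubstituted phenyl would also help show whether the halogen itself separates the two sets.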